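The source may hold more compounds than are shown below. What is called first, only, known or untested is meant among the compounds shown, and "the series" means these compounds.

Measured in a functional assay on the whole organism with Rattus norvegicus as the target, at a dose of 100 mg/kg; a higher number here means more inhibition at the dose given (going by the name of the read-out), a lower number less inhibition:
- compound 1, `C/N=C(/NC#N)NCCCCn1nc(N(C)C)ccc1=O`, gives 26.3%
- compound 2, `C/N=C(/NC#N)NCCCCn1nc(N2CCCC2)ccc1=O`, gives -1%
- compound 3, `CC/N=C(/NC#N)NCCCCn1nc(C)ccc1=O`, gives 13.5%

Compound 3 stands second highest of the three numbers in this assay: compound 1 sits higher by a margin beyond the scatter, compound 2 lower by a margin beyond the scatter. Within the data shown here, the one single-point step among the measured compounds is a number 27.3 percentage points lower from compound 1 to compound 2 (beyond the scatter), pyrrolidin-1-yl in place of dimethylamino on an aromatic carbon. It concerns the substituent on the shared core, not the saturated chain carbon bound to a double-bonded nitrogen that changes here, and it does not bear on the step to compound 4.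

Compound 4, `C/N=C(/NC#N)NCCCCn1nc(C)ccc1=O`, differs from compound 3 in one place: hydrogen in place of methyl on a saturated chain carbon bound to a double-bonded nitrogen. Cut one bond further out, the same difference reads ethyl to methyl. Among the measured compounds shown here, no measured pair shows this change; the expectation rests on compound 3 alone. The step is expected to stay within the scatter: a number 3.5 percentage points higher from compound 3 to compound 4 (within the scatter). Compound 4 is estimated at 17%, with a range from 0% to 35%.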

Compound 4, a percentage reported as inhibition, in the whole organism at one dose (the size of the read-out at that dose, not a potency): 23.5%
Compound 4: middle estimate off by 6.5 percentage points, on the low side; measured number inside the range.
By their numbers in this assay, from the lowest: compound 2; then compounds 3, 4 and 1 (each within the scatter of the next, the first and the last beyond it).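

In this assay the ethyl to methyl change on the saturated chain carbon bound to a double-bonded nitrogen reads a number 10 percentage points higher from compound 3 to compound 4 (within the scatter) and so does not separate the two groups at this position. On the aromatic carbon, methyl in place of dimethylamino reads a number 2.8 percentage points lower from compound 1 to compound 4 (within the scatter) and methyl in place of pyrrolidin-1-yl reads a number 24.5 percentage points higher from compound 2 to compound 4 (beyond the scatter), which leaves methyl and dimethylamino level there and pyrrolidin-1-yl alone apart from both. Nothing available bears on the cause of these steps.

Open, as far as these compounds go, is whether a longer chain such as propyl, or a chain ending in an amine, would also stay level with ethyl and methyl at the saturated chain carbon. Also open, from the compounds shown here alone, is whether the ethyl to methyl result holds with dimethylamino on the aromatic carbon.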